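Removing the sugar from compound 2: working notes

The compounds below may be only part of what the source reports. "The series", "measured", "known", "first", "only" and "open" are said of these compounds alone.

Measured so far in a functional assay on HCT-15 cells (Homo sapiens) for cytotoxicity, read by sulforhodamine B assay; a lower number here means that less compound is needed, a higher number that more compound is needed for the effect:
compound 1, `C=C[C@@](C)(CC[C@H]1C(C)=CC[C@H]2C(C)(C)CCC[C@]12C)O[C@@H]1O[C@H](C)[C@H](O)[C@H](O)[C@H]1O`, gives 3.9 ug/mL
compound 2, `C=C[C@@](C)(CC[C@H]1C(C)=CC[C@H]2C(C)(C)CCC[C@]12C)O[C@@H]1O[C@@H](C)[C@@H](O)[C@H](O)[C@H]1O`, gives 3.2 ug/mL

Compound 2 holds the lower of the two numbers, but the step of a 1.2-fold lower number from compound 1 to compound 2 (0.09 log units; within the scatter) is within the scatter, so the two compounds are not separated on these data. The only thing that distinguishes them is the fact that compounds 1 and 2 differ only in the configuration as drawn, with the two changed stereocentres sitting in the sugar ring.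

Compound 3, `C=C[C@](C)(O)CC[C@H]1C(C)=CC[C@H]2C(C)(C)CCC[C@]12C`, has not been measured in this assay. Set against compound 2 the change is a hydrogen atom in place of a group of 10 heavy atoms (6 carbon, 4 oxygen; one six-membered non-aromatic ring with 1 hetero atom), on an oxygen on a saturated carbon. Within the data shown here, no measured step bears directly on this change: the one step available, a 1.2-fold lower number from compound 1 to compound 2 (0.09 log units; within the scatter), alters only the configuration inside the group that leaves and was itself within the scatter. Whether losing the whole sugar changes the number is therefore open, and the expectation can only be anchored on compound 2 with a wide range.

Compound 3 is expected to give about 6 ug/mL, within 2 ug/mL to 20 ug/mL. The step this estimate implies, a 1.9-fold higher number from compound 2 to compound 3 (0.27 log units; within the scatter), is expected to be small, with a slight lean toward a higher number.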

Compound 3, concentration for half-maximal effect: 9.1 ug/mL
Beside the measured number, compound 3's estimate is 1.5-fold (0.18 log units) below it; the range from low to high includes it.
By their numbers in this assay, from the lowest: compounds 2 and 1 (each within the scatter of the next); then compound 3.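

In this assay, this position, an oxygen on a saturated carbon, now has its first reading: with a hydrogen atom in place of the group of 10 heavy atoms, the result is a 2.8-fold higher number from compound 2 to compound 3 (0.45 log units; beyond the scatter), and the same change read from the other sugar configuration is a 2.3-fold higher number from compound 1 to compound 3 (0.37 log units; beyond the scatter). Both steps are modest but beyond the scatter, so the presence of the group at this position registers in the number, whereas the configuration inside the group had not separated compound 1 from compound 2. The two readings point the same way and start from compounds alike in all but one respect: the fact that compounds 1 and 2 differ only in the configuration as drawn.

The compounds shown leave open which part of the leaving group carries the difference, for instance whether a methyl or an acetyl group on that oxygen would read nearer to compound 2 or to compound 3. Also open, on these data alone, is whether a sugar bearing an amine or a carboxylic acid in place of one of its hydroxyl groups would keep the number of compound 2 or move it.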